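This account rests on a few compounds, and the source may have more. Where it says the series, first, only, none or still open, it means among the compounds named here.

Working notes on the series. Three compounds sharing one core have been run in a functional assay on SGC-7901 cells (Homo sapiens) for antiproliferative activity, read by MTT assay, with a stated time of 72 h; on this read-out higher numbers stand for weaker inhibition and lower numbers for stronger inhibition. Compound 2 `COc1cc(-n2cnc3ccc(-c4ccc(C(F)(F)F)cc4)cc32)cc(OC)c1OC` gives 890 nM. Compound 1 `COc1cc(-n2cnc3ccc(-c4cccc(F)c4)cc32)cc(OC)c1OC` gives 2490 nM, and compound 3 `COc1ccccc1-c1ccc2ncn(-c3cc(OC)c(OC)c(OC)c3)c2c1` gives 5050 nM. Among these three numbers compound 2 stands lowest, the steps of a 2.8-fold lower number from compound 1 to compound 2 (0.45 log units; beyond the scatter) and a 5.7-fold higher number from compound 2 to compound 3 (0.75 log units; beyond the scatter) both lying beyond the scatter; the remaining step is a 2.0-fold higher number from compound 1 to compound 3 (0.31 log units; beyond the scatter).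

Compound 4 `COc1cc(-n2cnc3ccc(-c4cccc(C)c4)cc32)cc(OC)c1OC` is still to be measured. Relative to compound 2 the change is 3-methylphenyl in place of 4-(trifluoromethyl)phenyl on an aromatic carbon. Among the measured compounds shown here, no measured step exchanges a trifluoromethyl for a methyl on this ring, so the bearing steps are indirect: a 2.8-fold lower number from compound 1 to compound 2 (0.45 log units; beyond the scatter) shows that going from 3-fluorophenyl to 4-(trifluoromethyl)phenyl lowered the number, and a 5.7-fold higher number from compound 2 to compound 3 (0.75 log units; beyond the scatter) that going from 4-(trifluoromethyl)phenyl to 2-methoxyphenyl raised it. Leaving the 4-(trifluoromethyl)phenyl is thus expected to give a modestly higher number, estimated as a 2.2-fold higher number from compound 2 to compound 4 (0.35 log units; beyond the scatter). For compound 4 the estimate is 2000 nM, with an expected range from 800 nM to 5000 nM.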

Compound 4, half-maximal inhibitory concentration: 1240 nM
Beside the measured number, compound 4's estimate is 1.6-fold (0.21 log units) above it; low and high end bracket the measured number.
By their numbers in this assay, from the lowest: compounds 2, 4 and 1 (each within the scatter of the next, the first and the last beyond it); then compound 3.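

In this assay the exchange of 4-(trifluoromethyl)phenyl for 3-methylphenyl, with a 1.4-fold higher number from compound 2 to compound 4 (0.14 log units; within the scatter) as its step, does not separate the two groups at this position. Methyl in place of fluoro, with a 2.0-fold lower number from compound 1 to compound 4 (0.30 log units; within the scatter) as its step, does not separate compound 4 from compound 1 either, so compound 4 sits within the scatter of both compounds whose gap was the clearest among the non-methoxy aryl groups. Among the compounds shown here, the 2-methoxyphenyl group stays apart from the 3-methylphenyl group, with a 4.1-fold lower number from compound 3 to compound 4 (0.61 log units; beyond the scatter) as the step, and compound 3 remains the only compound beyond the scatter of all others.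

No data on any property of these groups bear on these differences. On these data alone, whether an amine, a carboxylic acid or a longer chain on this ring would move the number in this assay remains open.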